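The compounds below may be only part of what the source reports. "The series", "measured", "known", "first", "only" and "open" are said of these compounds alone.

Measured so far in a functional assay on KYSE-450 cells (Homo sapiens) for inhibition, read by MTT assay, with a stated time of 48 h; a lower number here means a stronger inhibitor, a higher number a weaker inhibitor:
Compound 1 `C=C(C)C(=O)N(Cc1ccc(OC)c(O)c1)c1cc(OC)c(OC)c(OC)c1` gives 200 nM.
Compound 2 `COc1ccc(CN(C(=O)C(C)C)c2cc(OC)c(OC)c(OC)c2)cc1O` gives 390 nM.
Compound 3 `C=CC(=O)N(Cc1ccc(OC)c(O)c1)c1cc(OC)c(OC)c(OC)c1` gives 160 nM.

Compound 3 has the lowest number of the three, but its gap to compound 1 is within the scatter, so the two cannot be ranked; only compound 2 sits clearly apart, by a 2.4-fold lower number from compound 2 to compound 3 (0.39 log units; beyond the scatter).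

Compound 4 `COc1ccc(CN(C(=O)CBr)c2cc(OC)c(OC)c(OC)c2)cc1O` is the next step from compound 3. The change is bromomethyl in place of vinyl on a carbonyl carbon.

Going by the values given here, every measured step so far has swapped the group on this same carbonyl carbon. The swaps gave a 2.0-fold higher number from compound 1 to compound 2 (0.29 log units; within the scatter) and a 1.3-fold lower number from compound 1 to compound 3 (0.10 log units; within the scatter), both within the scatter, and a 2.4-fold lower number from compound 2 to compound 3 (0.39 log units; beyond the scatter), a modest change. Among the compounds with values here, none of them involved bromomethyl, so no measured step directly tells what it will do; what the three steps show is that changes at this position have moved the number by at most a modest amount. The expectation is therefore a step of a 1.6-fold higher number from compound 3 to compound 4 (0.19 log units; within the scatter), with no clear direction beyond the scatter. Compound 4 is estimated to give 250 nM, with a range from 100 nM to 700 nM.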

Compound 4, half-maximal inhibitory concentration: 120 nM
Estimate against measurement, compound 4: 2.1-fold (0.32 log units) above; the measured number falls inside the stated range.
By their numbers in this assay, from the lowest: compounds 4, 3, 1 and 2 (each within the scatter of the next, the first and the last beyond it).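

Bromomethyl shows that a double bond in the group on this carbonyl carbon is not required for a low number in this assay, since replacing vinyl leaves the result within the scatter (a 1.3-fold lower number from compound 3 to compound 4 (0.12 log units; within the scatter)), and the same holds against 1-methylethenyl (a 1.7-fold lower number from compound 1 to compound 4 (0.22 log units; within the scatter)). Compound 2 goes against any simple reading by double bond alone: its isopropyl group also lacks one, yet bromomethyl in its place gives a modest step beyond the scatter (a 3.3-fold lower number from compound 2 to compound 4 (0.51 log units; beyond the scatter)). No measurement here explains these differences.

The compounds shown leave open how chloromethyl, a longer chain such as bromoethyl, or an aminomethyl group on this carbonyl carbon would compare. They also leave open whether the same order of compounds 1 to 4 would hold on any other cell line.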